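This account rests on a few compounds, and the source may have more. Where it says the series, first, only, none or still open, it means among the compounds named here.

In a functional assay on the whole organism (Hindlimb, strain albino) with Mus musculus as the target, in the maximal electroshock model, with a stated time of 0.5 h (on this read-out lower numbers stand for an effect already at smaller amounts and higher numbers for an effect only at larger amounts of compound), compound 1 (`CC(=O)N1N=C(Nc2nc3ccccc3s2)CC1c1ccccc1`) gives 315 umol/kg. Compound 2 (`CC(=O)N1N=C(Nc2nc3ccc(C)cc3s2)CC1c1ccccc1`) gives 106 umol/kg, and compound 3 (`CC(=O)N1N=C(Nc2nc3ccc([N+](=O)[O-])cc3s2)CC1c1ccccc1`) gives 216 umol/kg. Compound 1 thus stands at the upper end of these numbers together with compound 3, the two lying within the scatter of each other, while compound 2 lies lower.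

Compound 4 (`CC(=O)N1N=C(Nc2nc3ccccc3s2)CC1c1ccc(O)cc1`) keeps the core of compound 1 and changes only the phenyl group: hydroxy in place of hydrogen on an aromatic carbon. This is hydroxy in place of hydrogen on an aromatic carbon, para to a large group, or phenyl to 4-hydroxyphenyl.

The measured steps bear on this only loosely, since each also places a group on an aromatic carbon, but elsewhere in the core. The step of a 3.0-fold lower number from compound 1 to compound 2 (0.47 log units; beyond the scatter) is modest, and the step of a 1.5-fold lower number from compound 1 to compound 3 (0.16 log units; within the scatter) stays within the scatter. The gap a 2.0-fold higher number from compound 2 to compound 3 (0.31 log units; beyond the scatter) is also modest. No change on the phenyl group and no hydroxy group has been measured in this series.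

In this assay a small move toward a lower number is therefore expected, most likely within the scatter and no larger than modest. The expected step is a 1.5-fold lower number from compound 1 to compound 4 (0.18 log units; within the scatter). For compound 4 the estimated value is 210 umol/kg, with an expected range from 90 umol/kg to 450 umol/kg.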

Compound 4, dose for half-maximal effect: 249 umol/kg
Beside the measured number, compound 4's estimate is 1.2-fold (0.07 log units) below it, and the stated range covers the measured number.
By their numbers in this assay, from the lowest: compound 2; then compounds 3, 4 and 1 (each within the scatter of the next).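

Hydroxy in place of hydrogen, para to a large group, is the first change on the phenyl group of the series, and it gives a 1.3-fold lower number from compound 1 to compound 4 (0.10 log units; within the scatter) in this assay and so leaves compounds 1 and 4 within the scatter of each other. Among the compounds shown here, of the earlier steps that add a group to the core of compound 1, the methyl of compound 2 gives a 3.0-fold lower number from compound 1 to compound 2 (0.47 log units; beyond the scatter) and the nitro of compound 3 gives a 1.5-fold lower number from compound 1 to compound 3 (0.16 log units; within the scatter) at a different place, so only the methyl step lies beyond the scatter, and the hydroxy result now shows that this position on the phenyl group accepts a group with a hydrogen-bond donor and acceptor without a step beyond the scatter. No measurement at hand speaks to the reason for this result.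

A single substituent at a single position on the phenyl group cannot show whether this holds for other groups there, such as methoxy, an amine or a carboxylic acid. As far as these compounds go, it also remains open whether hydroxy at this position and the methyl of compound 2 would combine in one compound.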